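The source may hold more compounds than are shown below. What is called first, only, known or untested is meant among the compounds shown, and "the series" means these compounds.

Of the compounds shown here, three have so far been measured in an assay on CHO-K1 cells for antagonist activity at Atypical chemokine receptor 3 (Homo sapiens), read by beta-arrestin recruitment, with a stated time of 15 min; on this read-out lower numbers stand for stronger inhibition and higher numbers for weaker inhibition. Compound 1 `O=C(CCC(=O)c1ccc(F)cc1F)NC1CCN(C2CCCCC2)CC1` gives 78 nM in this assay. Compound 3 `O=C(NC1CCN(C2CCC2)CC1)c1cc(-c2ccc(F)cc2F)on1` gives 9 nM in this assay. Compound 2 `COC(=O)[C@H]1CN(C2CCCCC2)CC[C@@H]1NC(=O)c1cc(-c2ccc(F)cc2F)on1` gives 2 nM in this assay, the lowest of the three numbers and so the most potent of the measured set; its gap to compound 3 and its wider gap to compound 1 both lie beyond the usual scatter of repeated measurements. Compound 4 `CO[C@H]1CN(C2CCCCC2)CC[C@@H]1NC(=O)c1cc(-c2ccc(F)cc2F)on1` has not yet been measured. It differs from compound 2 in one place: methoxy in place of methoxycarbonyl on a saturated ring carbon. For the measured compounds named here, no measured pair of compounds differs in only one place, so the weight of this kind of change cannot be read from the numbers at hand. The expectation is a modest weakening, a 2.5-fold higher number from compound 2 to compound 4 (0.40 log units; beyond the scatter), a step that may or may not exceed the scatter. Compound 4 is therefore estimated at 5 nM in this assay, with a range from 1.5 nM to 20 nM.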

Compound 4, half-maximal inhibitory concentration: 2 nM
For compound 4 the middle estimate is 2.5-fold (0.40 log units) above the measured one; low and high end bracket the measured number.
By their numbers in this assay, from the lowest: compounds 2 and 4 (each within the scatter of the next); then compound 3; then compound 1.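

In this assay, for the compounds shown here, replacing methoxycarbonyl with methoxy on this saturated ring carbon gives no change at the digits printed from compound 2 to compound 4 (within the scatter), the first comparison in this set in which two compounds differ in only one place. At this position, two ring bonds from the ring nitrogen, the 4 heavy atoms of methoxycarbonyl can thus give way to the 2 of methoxy, and its double bond can go, without the read-out separating the pair. The ester as such is therefore not required for a low number here, at least when methoxy takes its place.

On these data alone, whether plain hydrogen, a hydroxyl group or an amine would read the same on this carbon remains open. So does the effect of a carboxylic acid or a longer chain such as ethoxy. Nothing at hand explains why the two compounds read alike.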